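Swapping the oxetane for a propyl chain on compound 3

This account rests on a few compounds, and the source may have more. Where it says the series, first, only, none or still open, it means among the compounds named here.

Of the compounds shown here, three sharing one core have been tested in a functional assay on CHO cells for antagonist activity at C-C chemokine receptor type 4 (Homo sapiens), read by radioligand binding and GTPgammaS binding; on this read-out lower numbers stand for stronger inhibition and higher numbers for weaker inhibition. Compound 1 `COc1cc2[nH]c(=O)[nH]c2cc1NS(=O)(=O)c1cccc(Cl)c1Cl` carries a hydrogen on the aromatic nitrogen and gives 316 nM. Compound 2 `COc1cc2c(cc1NS(=O)(=O)c1cccc(Cl)c1Cl)[nH]c(=O)n2C(C)C` carries an isopropyl there and gives 1000 nM. Compound 3 `COc1cc2c(cc1NS(=O)(=O)c1cccc(Cl)c1Cl)[nH]c(=O)n2C1COC1` carries an oxetan-3-yl and gives 112 nM, the lowest of the three numbers: it stands a 2.8-fold lower number from compound 1 to compound 3 (0.45 log units; beyond the scatter) and an 8.9-fold lower number from compound 2 to compound 3 (0.95 log units; beyond the scatter).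

Compound 4 `CCCn1c(=O)[nH]c2cc(NS(=O)(=O)c3cccc(Cl)c3Cl)c(OC)cc21` has not been measured. It differs from compound 3 in one place: propyl in place of oxetan-3-yl on an aromatic nitrogen. The new group is a plain chain with no ring.

Among the measured compounds shown here, two measured steps bear on this change. Replacing the oxetan-3-yl with the branched isopropyl runs opposite to the step of an 8.9-fold lower number from compound 2 to compound 3 (0.95 log units; beyond the scatter), that is, it is a clear worsening. Removing the group entirely runs opposite to the step of a 2.8-fold lower number from compound 1 to compound 3 (0.45 log units; beyond the scatter), again a worsening. Both moves away from the oxetane raised the number, so a move to propyl, another chain without a ring, is expected to raise it as well, by a modest amount beyond the scatter, a 4.0-fold higher number from compound 3 to compound 4 (0.60 log units; beyond the scatter).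

Compound 4 is therefore estimated at 450 nM in this assay, with a likely range from 150 nM to 1400 nM.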

Compound 4, half-maximal inhibitory concentration: 3980 nM
Compound 4: the middle estimate sits 8.8-fold (0.95 log units) below what was measured; measured number above the stated range.
By their numbers in this assay, from the lowest: compound 3; then compound 1; then compound 2; then compound 4.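

In this assay, the change from oxetan-3-yl to propyl gives the largest step among these four compounds (a 36-fold higher number from compound 3 to compound 4 (1.55 log units; beyond the scatter)), so this spot on the aromatic nitrogen responds far more strongly to the choice of group than the first three compounds suggested. The shape of the chain also counts, since the unbranched propyl does worse than the branched isopropyl (a 4.0-fold higher number from compound 2 to compound 4 (0.60 log units; beyond the scatter)). Propyl is also clearly worse than plain hydrogen (a 13-fold higher number from compound 1 to compound 4 (1.10 log units; beyond the scatter)), so among the groups shown both ringless carbon chains raise the number relative to hydrogen, and only oxetan-3-yl lowers it.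

Nothing measured here explains why these groups differ so much. The compounds shown also leave open whether the low number of compound 3 goes with the four-membered ring or with its oxygen, a question that a cyclobutyl group, which keeps the ring without the oxygen, and a methoxyethyl chain, which keeps an oxygen without the ring, could separate.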